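This account rests on a few compounds, and the source may have more. Where it says the series, first, only, none or still open, it means among the compounds named here.

Working notes on the series in a functional assay on M14 cells (Homo sapiens) for cytotoxicity; on this read-out higher numbers stand for weaker inhibition of growth and lower numbers for stronger inhibition of growth. Compound 1 `COc1ccc(C2=C(c3cc(OC)c(OC)c(OC)c3)CC3CCCN3C2=O)cc1O` returns only a limit, > 100000 nM, and not a number. Compound 2 `CSc1ccc(C2=C(c3ccc(F)c(F)c3)C(=O)N3CCCC3C2)cc1` gives 300 nM. Compound 3 `CSc1ccc(C2=C(c3ccc(F)c(C)c3)C(=O)N3CCCC3C2)cc1` gives 800 nM, the higher of the two actual numbers. Among the measured compounds shown here, the one measured step, a 2.7-fold higher number from compound 2 to compound 3 (0.43 log units; beyond the scatter), is modest and replaces fluoro with methyl on an aromatic carbon. Compound 4 `CSc1ccc(C2=C(c3ccc(Br)cc3)C(=O)N3CCCC3C2)cc1` is unmeasured and differs from compound 3 at that same aryl substituent: 4-bromophenyl in place of 4-fluoro-3-methylphenyl on a double-bonded ring carbon. For the measured compounds named here, with the methyl gone, a modest step of about that size toward a lower number is expected in this assay, although no measured compound carries bromine. The expected change is a 2.0-fold lower number from compound 3 to compound 4 (0.30 log units; within the scatter). For compound 4 the estimate is 400 nM, with an expected range of 120 nM to 1300 nM.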

Compound 4, concentration for 50% growth inhibition: 9000 nM
The estimate for compound 4 lay 23-fold (1.35 log units) below the measured number; the whole stated range lies below it.
By their numbers in this assay, from the lowest: compound 2; then compound 3; then compound 4. At a limit, above all of these: compound 1.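

At this double-bonded ring carbon, the aryl group can shift the number far more than the earlier fluoro-to-methyl change suggested: 4-bromophenyl gives an 11-fold higher number from compound 3 to compound 4 (1.05 log units; beyond the scatter) and, against 3,4-difluorophenyl, a 30-fold higher number from compound 2 to compound 4 (1.48 log units; beyond the scatter), both large beside the modest 2.7-fold higher number from compound 2 to compound 3 (0.43 log units; beyond the scatter). Nothing measured in the series accounts for this rise.

The compounds shown leave open whether the rise follows from bromine replacing fluorine or from the loss of the second ring substituent, as compound 4 differs in both. A 4-fluorophenyl or 4-chlorophenyl group at this carbon would separate the two.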